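Sulfonamides Tested Against Mitochondrial Malate Dehydrogenase

This account rests on a few compounds, and the source may have more. Where it says the series, first, only, none or still open, it means among the compounds named here.

Measured compounds:
compound 1, `O=S(=O)(Nc1ccc(-c2nc3ccccc3o2)cc1)c1cccc(F)c1` — > 63000 nM
compound 2, `O=S(=O)(Nc1ccc(-c2nc3ccccc3o2)cc1)c1ccc(O)cc1` — > 63000 nM

Two compounds built on the shared core have been examined in an assay on isolated protein for inhibition of malate dehydrogenase, mitochondrial (Sus scrofa), with stated times of 45 min and 30 min; a lower number here means a stronger inhibitor, a higher number a weaker inhibitor. In this assay compound 1 gives only a limit, > 63000 nM. Compound 2 also gives only a limit, > 63000 nM. The step that the two limits leave unreadable from compound 1 to compound 2 cannot be read because of the limit of > 63000 nM in this assay, at which 2 of the 2 values shown sit. Going by the values given here, compound 2 thus stands at the upper limit of this assay, with no number of its own and no measured step that tells which way a change on the sulfonyl sulfur moves potency.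

The next compound, compound 3, `COc1ccccc1S(=O)(=O)Nc1ccc(-c2nc3ccccc3o2)cc1`, carries the change (2-methoxyphenyl in place of 4-hydroxyphenyl on a sulfonyl sulfur). Among the compounds with values here, the only measured step that touches the same place is the one from compound 1 to compound 2, and its size is not readable. Within the data shown here, no measured step therefore bears on this change in a way that allows a direction or size to be predicted in this assay; the expectation for compound 3 is that it will again sit at the limit rather than give a number. Compound 3 is expected to give 63000 nM, with a range of 20000 nM to 200000 nM. The expected step is a number no higher from compound 2 to compound 3 (the limit leaves the size open).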

Compound 3, half-maximal inhibitory concentration: > 63000 nM
Compound 3 ended at the assay's limit; the forecaster's own chance of this, stated with the estimate: 85%; the middle value sits exactly at the limit.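

In this assay compound 3 also gives only a limit of > 63000 nM and no number of its own. The steps from compound 1 and from compound 2 to compound 3 cannot be read, because all three compounds stand at the same limit: the limit of > 63000 nM in this assay, at which 3 of the 3 values shown sit.
The compounds shown leave open whether any group on the sulfonyl sulfur moves potency, and in which direction.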